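A few compounds are considered here, and "the series" means these few. Any claim that something is new, unique, unknown or untested is made for them only; others in the source may bear on it.

Compound 1 `COc1ccc(N2CCN(Cc3csc(N)c3C(=O)c3ccc(Cl)cc3)CC2)cc1` gives 0% in a functional assay on CHO cells with adenosine receptor A1 (Homo sapiens) as the target, read by cAMP accumulation and immunoassay, with a stated time of 6 min, tested at 0.1 uM; on this read-out lower numbers stand for a stronger effect and higher numbers for a weaker effect at the one concentration tested.
Compound 2 `Nc1scc(CN2CCN(c3ccccc3C(F)(F)F)CC2)c1C(=O)c1ccc(Cl)cc1` gives -7.5% in this assay.
Compound 3 `Nc1scc(CN2CCN(c3cccc4ccccc34)CC2)c1C(=O)c1ccc(Cl)cc1` gives 0% in this assay.

Compound 3 sits level with compound 1 at the digits given, and the two of them are the highest of the three numbers; compound 2 is the furthest away, and the step between them is a number 7.5 percentage points higher from compound 2 to compound 3 (within the scatter). Going by the values given here, every step so far exchanges the aryl group on the ring nitrogen of the shared core, and none of them leaves the scatter: a number 7.5 percentage points lower from compound 1 to compound 2 (within the scatter) and no change at the digits printed from compound 1 to compound 3 (within the scatter).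

Compound 4 `Nc1scc(CN2CCN(c3cccc(F)c3F)CC2)c1C(=O)c1ccc(Cl)cc1` differs from compound 3 by 2,3-difluorophenyl in place of naphthalen-1-yl on an amine nitrogen in a ring. This is the same kind of exchange as the three steps already measured, all of which stayed within the scatter, so no step beyond the scatter is expected in this assay for compound 4. Compound 4 is therefore estimated at -2%, with a range from -15% to 12%. The expected step from compound 3 is a number 2 percentage points lower from compound 3 to compound 4 (within the scatter).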

Compound 4, a percentage reported as activity, at one concentration (the size of the read-out at that concentration, not a potency): -5.2%
The estimate for compound 4 lay 3.2 percentage points above the measured number; measured number inside the range.
By their numbers in this assay, from the lowest: compounds 2, 4, 1 and 3 (each within the scatter of the next).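

Replacing naphthalen-1-yl with the smaller, single-ring 2,3-difluorophenyl on the ring nitrogen gives a number 5.2 percentage points lower from compound 3 to compound 4 (within the scatter) in this assay, so losing one aromatic ring here produced no step beyond the scatter. The comparisons with the other aryl groups, a number 2.3 percentage points higher from compound 2 to compound 4 (within the scatter) and a number 5.2 percentage points lower from compound 1 to compound 4 (within the scatter), also stay within it, and a group with two fluorine atoms on the ring thus joins the trifluoromethyl, methoxy and fused-ring aryl groups without separating from them. Nothing measured here bears on why this position responds so little to these exchanges.

Going by these compounds, all four compounds carry an aryl group at this place, so it remains open whether a cyclohexyl ring, or a phenyl ring bearing a carboxylic acid or an amine, would move the number beyond the scatter. With only one concentration tested, any differences in potency among these four compounds also remain open.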